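This account rests on a few compounds, and the source may have more. Where it says the series, first, only, none or still open, it means among the compounds named here.

Compound 1 `CC(C)S(=O)(=O)OC1CCC(CN2CCN(c3cc(=O)c4cc(C(F)(F)F)cc([N+](=O)[O-])c4s3)CC2)CC1`: in an ADME assay on Vero cells (Chlorocebus sabaeus) for cytotoxicity, read by MTT assay, with a stated time of 48 h (a higher number here means a weaker inhibitor, a lower number a stronger inhibitor), compound 1 gives > 64 ug/mL, a limit of the assay.
Compound 2 `CC(=O)NC1CCC(CN2CCN(c3cc(=O)c4cc(C(F)(F)F)cc([N+](=O)[O-])c4s3)CC2)CC1`: in this assay compound 2 gives > 64 ug/mL, a limit of the assay.
Compound 3 `O=C(OC1CCC(CN2CCN(c3cc(=O)c4cc(C(F)(F)F)cc([N+](=O)[O-])c4s3)CC2)CC1)c1ccc(F)cc1`: in this assay compound 3 gives > 64 ug/mL, a limit of the assay.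

Compound 1 stands only at a limit in this assay, and the two other values shown stand at the same limit (the limit of > 64 ug/mL in this assay, at which 3 of the 3 values shown sit). The step from compound 1 to compound 4 `C=CC(=O)OC1CCC(CN2CCN(c3cc(=O)c4cc(C(F)(F)F)cc([N+](=O)[O-])c4s3)CC2)CC1` changes the ester end of the side chain: vinylcarbonyl in place of isopropylsulfonyl on an oxygen on a saturated carbon. The measured steps that bear on this position are a step that the two limits leave unreadable from compound 1 to compound 2, a step that the two limits leave unreadable from compound 1 to compound 3 and a step that the two limits leave unreadable from compound 2 to compound 3; all three are left unreadable because both values in each pair sit at a limit (the limit of > 64 ug/mL in this assay, at which 3 of the 3 values shown sit). A replacement at the same oxygen, (4-fluorophenyl)carbonyl in place of isopropylsulfonyl, therefore gave no readable step, and nothing in the data shows a move away from the limit in this assay on any change at this end of the chain. Compound 4 is accordingly expected to show no step beyond the scatter, with a step that the limit leaves unreadable from compound 1 to compound 4 the step that this estimate means, and the reading is most likely to remain a limit. For compound 4 the estimate is 80 ug/mL, with a range from 40 ug/mL to 160 ug/mL.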

Compound 4, half-maximal inhibitory concentration: > 64 ug/mL
Compound 4 gave a limit, no number; the forecaster's own chance of this, stated with the estimate: 80%; the middle value lies beyond the limit too.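

In this assay compound 4 gives > 64 ug/mL, a limit of the assay. Its steps to compound 1, compound 2 and compound 3 cannot be read, as all four compounds stand at one limit: the limit of > 64 ug/mL in this assay, at which 4 of the 4 values shown sit. The compounds shown leave open what number each would give in this assay, and whether any change at this end of the side chain shifts the reading.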